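The compounds below may be only part of what the source reports. "The series", "measured", "known", "first", "only" and "open" are said of these compounds alone.

In a functional assay on the whole organism (strain Wistar) with Rattus norvegicus as the target, with a stated time of 5 min (a lower number here means that less compound is needed, a higher number that more compound is needed for the effect), three related compounds have been tested so far. Compound 1 `CCC1(CCCCN2CCN(c3ccc(F)c(Cl)c3)CC2)C(=O)Nc2ccccc21` reaches only the limit of the test, giving > 20 mg/kg, which is a boundary rather than a number. Compound 2 `CCC1(CCCCCN2CCN(c3cccc(Cl)c3)CC2)C(=O)Nc2ccccc21` likewise stops at a limit, giving > 10 mg/kg. Compound 3 `CCC1(CCCCN2CCN(c3cccc(Cl)c3)CC2)C(=O)Nc2cc(F)c(Cl)cc21` gives a proper number, 20 mg/kg. Compound 1 therefore stands at one of two limits in this small set, namely (the limit of > 20 mg/kg in this assay, at which 1 of the 3 values shown sits), while the other is the limit of > 10 mg/kg in this assay, at which 1 of the 3 values shown sits. No pair among these measured compounds differs in a single place, so no measured step exists to lean on.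

Compound 4 `CCC1(CCCCN2CCN(c3ccccc3)CC2)C(=O)Nc2ccccc21` differs from compound 1 in one place: phenyl in place of 3-chloro-4-fluorophenyl on an amine nitrogen in a ring. Among the measured compounds shown here, with no measured step of this kind to draw on in this assay, the expectation is a change no larger than the usual scatter, in no firm direction, so that compound 4 is expected to sit near the same limit. The estimate for compound 4 is 20 mg/kg, with a range from 5 mg/kg to 60 mg/kg. This would mean an expected step of a number no higher from compound 1 to compound 4 (the limit leaves the size open).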

Compound 4, minimum effective dose: 10 mg/kg
Beside the measured number, compound 4's estimate is 2.0-fold (0.30 log units) above it, and the stated range covers the measured number.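

In this assay, the plain phenyl group gives an at least 2.0-fold lower number from compound 1 to compound 4 (0.30 log units; that floor lies within the scatter). Compound 4 gives 10 mg/kg, a measured number, so on this ring nitrogen the chlorine and fluorine of the 3-chloro-4-fluorophenyl group are not needed for an effect to be measured, and the plain phenyl group offers a usable reference point. The true size of the step stays open because compound 1 rests on a limit and not on a number: the limit of > 20 mg/kg in this assay, at which 1 of the 4 values shown sits.

The compounds shown leave open whether the chlorine or the fluorine alone would behave like the pair. They also leave open how a methoxy group or a nitrile on this phenyl ring would compare with compound 4.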